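This account rests on a few compounds, and the source may have more. Where it says the series, first, only, none or still open, it means among the compounds named here.

Working notes on the series. All three measured compounds share one core in which an amide nitrogen carries a methyl group; the substituent on the amide carbonyl varies. In a functional assay on KB cells (Homo sapiens) for antiproliferative activity, read by MTT assay, with a stated time of 72 h (on this read-out higher numbers stand for weaker inhibition and lower numbers for stronger inhibition), compound 1 `CC(=O)N(C)c1ccc2[nH]c(-c3n[nH]c4ccccc34)cc2n1` gives 10300 nM, and compound 2 `CCC(=O)N(C)c1ccc2[nH]c(-c3n[nH]c4ccccc34)cc2n1` gives 9300 nM; the step of a 1.1-fold lower number from compound 1 to compound 2 (0.04 log units; within the scatter) is within the scatter. Compound 3 `CN(C(=O)c1ccc(Br)cc1)c1ccc2[nH]c(-c3n[nH]c4ccccc34)cc2n1` gives 1780 nM, the lowest of the three numbers, and the steps of a 5.8-fold lower number from compound 1 to compound 3 (0.76 log units; beyond the scatter) and a 5.2-fold lower number from compound 2 to compound 3 (0.72 log units; beyond the scatter) both lie beyond the scatter, so compound 3 stands apart from the two alkyl amides.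

Compound 4 `COc1ccc(C(=O)N(C)c2ccc3[nH]c(-c4n[nH]c5ccccc45)cc3n2)cc1` differs from compound 3 by methoxy in place of bromo on an aromatic carbon. For the measured compounds named here, none of the measured steps bears directly on this change: the steps from the alkyl amides to compound 3 concern an aryl group replacing an alkyl chain, and the step between compound 1 and compound 2 concerns chain length. The data hold nothing on swapping a substituent on the aryl ring. Since the aryl amide is kept, compound 4 is expected to stay near compound 3, with no step beyond the scatter in either direction. The expected step is a 1.1-fold higher number from compound 3 to compound 4 (0.05 log units; within the scatter). For compound 4 the estimate is 2000 nM, within a range from 700 nM to 6000 nM.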

Compound 4, half-maximal inhibitory concentration: 12900 nM
Estimate against measurement, compound 4: 6.5-fold (0.81 log units) below; the whole stated range lies below it.
By their numbers in this assay, from the lowest: compound 3; then compounds 2, 1 and 4 (each within the scatter of the next).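

In this assay the aryl substituent carries weight: at this aromatic carbon, para to a large group, methoxy in place of bromo gives a 7.2-fold higher number from compound 3 to compound 4 (0.86 log units; beyond the scatter) and shows that keeping an aryl amide does not by itself keep the number of compound 3. Both a 1.3-fold higher number from compound 1 to compound 4 (0.10 log units; within the scatter) and a 1.4-fold higher number from compound 2 to compound 4 (0.14 log units; within the scatter) lie within the scatter, so with 4-methoxyphenyl on the carbonyl the separation from the alkyl amides seen with 4-bromophenyl is gone, and the aryl-for-alkyl step depends on the substituent the ring carries. No measurement at hand accounts for the difference between bromo and methoxy.

Still open, from the compounds shown here alone, is whether an unsubstituted phenyl would stand with compound 3 or with compound 4, and how chloro, hydroxy or an amine would read at this position. The compounds shown also leave open what hydrogen in place of the methyl on the amide nitrogen would do.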